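Capping the hydroxy group of compound 1

This account rests on a few compounds, and the source may have more. Where it says the series, first, only, none or still open, it means among the compounds named here.

Compound 1 `COc1ccc(-c2oc3ccc(NC(C)=O)cc3c(=O)c2O)cc1`: 9000 nM
Compound 2 `CC(=O)Nc1ccc2oc(-c3ccccc3F)c(O)c(=O)c2c1`: 47000 nM
Compound 3 `CC(=O)Nc1ccc2oc(-c3ccc(F)cc3)c(O)c(=O)c2c1`: 26000 nM

In an ADME assay on THP-1 cells (Homo sapiens) for cytotoxicity, read by flow cytometry and propidium iodide staining, with a stated time of 72 h (on this read-out higher numbers stand for weaker inhibition and lower numbers for stronger inhibition), compound 1 gives the lowest number of the three, and both of its steps lie beyond the scatter: a 2.9-fold higher number from compound 1 to compound 3 (0.46 log units; beyond the scatter) and a 5.2-fold higher number from compound 1 to compound 2 (0.72 log units; beyond the scatter). Between the other two, a 1.8-fold lower number from compound 2 to compound 3 (0.26 log units; within the scatter) stays within the scatter. Compound 4 `COc1ccc(-c2oc3ccc(NC(C)=O)cc3c(=O)c2OC)cc1` differs from compound 1 by methyl in place of hydrogen on an oxygen on an aromatic ring, turning hydroxy to methoxy. Within the data shown here, no measured step touches that oxygen, so the two modest steps from compound 1 bear on it only indirectly. Both went to higher numbers, and a small step the same way is expected. The expected step, resting on little evidence, is a 1.8-fold higher number from compound 1 to compound 4 (0.25 log units; within the scatter). For compound 4 the estimated value is 16000 nM, with an expected range from 5000 nM to 50000 nM.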

Compound 4, half-maximal inhibitory concentration: > 50000 nM
Compound 4: no number, only a limit; the forecaster's own chance of this, stated with the estimate: 15%; at least 3.1-fold (0.49 log units) between middle value and limit.
By their numbers in this assay, from the lowest: compound 1; then compounds 3 and 2 (each within the scatter of the next). At a limit, above all of these: compound 4.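

Turning hydroxy to methoxy gives an at least 5.5-fold higher number from compound 1 to compound 4 (0.74 log units; beyond the scatter) in this assay, so this oxygen, which no earlier step touched, clearly bears on the read-out. Compound 4 has no number here, only a limit, so the full size of the step stays unknown: the limit of > 50000 nM in this assay, at which 1 of the 4 values shown sits.

Open, on these data alone, is how an ethyl group, a longer chain, an acetyl group or a chain carrying an amine would read on this oxygen. Also open, as far as these compounds go, is whether the same change on compound 2 or compound 3 would go the same way.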